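This account rests on a few compounds, and the source may have more. Where it says the series, first, only, none or still open, it means among the compounds named here.

Of the compounds shown here, three built on a shared core have been measured in a physicochemical assay for lipophilicity, read by HPLC; a lower number here means a more polar compound, a higher number a more lipophilic compound. Compound 1 `Cc1ccc(CNC(=O)C(CCN)N(C)CCC=C(c2sccc2C)c2sccc2C)cc1` gives 6.61. Compound 2 `Cc1ccc(CNC(=O)C(CC(C)O)N(C)CCC=C(c2sccc2C)c2sccc2C)cc1` gives 6.15 in this assay, and compound 3 `Cc1ccc(CNC(=O)C(CCO)N(C)CCC=C(c2sccc2C)c2sccc2C)cc1` gives 6.2 in this assay. Both changes leading away from compound 1 lowered the number: a number 0.46 log units lower from compound 1 to compound 2 (beyond the scatter) and a number 0.41 log units lower from compound 1 to compound 3 (beyond the scatter), whereas a number 0.05 log units higher from compound 2 to compound 3 (within the scatter). Compound 3 therefore stands second highest of the three, with compound 2 within the scatter of it and compound 1 beyond it.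

Compound 4 `Cc1ccsc1C(=CCCN(C)C(CCO)C(=O)NC(C)c1ccccc1)c1sccc1C` is the next compound to be measured in this assay. It differs from compound 3 in one place: 1-phenylethyl in place of 4-methylbenzyl on an amide-type nitrogen. Within the data shown here, none of the three measured steps touches this part of the molecule; all of them concern the hydroxy or amino group, so no measured step bears directly on this change. Since the two groups hold the same atoms joined differently and neither carries a hydrogen-bond donor or acceptor, the expected step is none beyond the scatter: no change at the digits printed from compound 3 to compound 4 (within the scatter). Compound 4 is thus estimated to give 6.2 in this assay, with a range from 5.9 to 6.5.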

Compound 4, partition coefficient: 6.1
Estimate against measurement, compound 4: 0.10 log units above; low and high end bracket the measured number.
By their numbers in this assay, from the lowest: compounds 4, 2 and 3 (each within the scatter of the next); then compound 1.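

Among these compounds, the earlier compounds differ only at the hydroxy or amino end of the side chain, so this is the first view of the group on the amide-type nitrogen. In this assay, putting 1-phenylethyl in place of 4-methylbenzyl gives a number 0.10 log units lower from compound 3 to compound 4 (within the scatter), so these two groups, each with 8 carbon atoms and one six-membered aromatic ring, cannot be told apart by this measurement. No measured information here offers an explanation for this result.

From the compounds shown here alone, it remains open whether a group of a different kind on this nitrogen, such as a benzyl carrying a carboxylic acid or an amine on its ring, would move the number beyond the scatter. Going by these compounds, it is also open whether the same swap would read alike on compound 1, which has the amino group.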